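The source may report more compounds than this note shows. Statements on the series, on what has been measured and on what is new or still open speak of the compounds shown alone.

Of the compounds shown here, three sharing one core have been measured in an assay on isolated protein for inhibition of 11-beta-hydroxysteroid dehydrogenase type 2 (Homo sapiens), read by scintillation proximity assay, tested at 10 uM; on this read-out lower numbers stand for less inhibition and higher numbers for more inhibition at the one concentration tested (going by the name of the read-out). Compound 1, `CCN1CCN(C(=O)CC2CCCCC2)CC1`, carries a cyclohexylmethyl on the carbonyl carbon; in this assay compound 1 gives 40%. Compound 2, `CCN1CCN(C(=O)C2CCCCC2)CC1`, has a cyclohexyl in that position; in this assay compound 2 gives 0%. Compound 3, `CCN1CCN(C(=O)C2CC2)CC1`, bears a cyclopropyl on the carbonyl carbon; in this assay compound 3 gives 0%.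

Compound 3 therefore stands level with compound 2 at the digits reported, the two of them together forming the low end of the three numbers, while compound 1 sits markedly higher, a gap well beyond the usual scatter. Going by the values given here, no step between measured compounds that differ in only one place is available, so no computed step can be quoted here.

Compound 4, `CCN1CCN(C(=O)C(C)(C)C)CC1`, is the next compound to be measured. Relative to compound 3 the change is tert-butyl in place of cyclopropyl on a carbonyl carbon.

Both compound 2 and compound 3 show small rings on the carbonyl carbon and no measurable inhibition, and compound 4 keeps a compact substituent there. The expected step from compound 3 to compound 4 in this assay is a number 5 percentage points higher from compound 3 to compound 4 (within the scatter), that is, no change beyond the scatter. Compound 4 is thus estimated at 5% in this assay, within a range from 0% to 20%.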

Compound 4, a percentage reported as inhibition, at one concentration (the size of the read-out at that concentration, not a potency): 0%
Compound 4: the middle estimate sits 5 percentage points above what was measured, within the range that was stated.
By their numbers in this assay, from the lowest: compounds 2, 3 and 4 (each within the scatter of the next); then compound 1.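

In this assay, going by these compounds alone, the replacement of cyclopropyl by tert-butyl on a carbonyl carbon gives no change at the digits printed from compound 3 to compound 4 (within the scatter), the first step in this set that can be read directly at this position. The step takes away the three-membered ring and puts an open, branched group with no ring in its place, yet the reading does not move, so at the one concentration tested the presence of a ring on the carbonyl carbon makes no visible difference between these two groups. Nothing measured here offers an explanation for this result.

Compound 1, at 40%, remains the only one of the four with a reading clearly away from the others, and the compounds shown do not tell whether a longer chain such as n-butyl, or a benzyl group, on the carbonyl carbon would give a similar reading. On these data alone, they also leave open how an amine or a carboxylic acid at this place would read in this assay, and since compound 3 and compound 4 were read at a single concentration, any difference between them at other concentrations remains unknown.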